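Adding an amino group to compound 1

The source may hold more compounds than are shown below. What is called first, only, known or untested is meant among the compounds shown, and "the series" means these compounds.

compound 1 `OC[C@H]1O[C@@H](n2cnc3c(N4CCN(c5ncccn5)CC4)ncnc32)[C@H](O)[C@@H]1O` gives 40000 nM
compound 2 `Cc1ccc(N2CCN(c3ncnc4c3ncn4[C@@H]3O[C@H](CO)[C@@H](O)[C@H]3O)CC2)cc1` gives > 100000 nM, which is a limit and not a number

Within the data shown here, in a functional assay on MCF7 cells (Homo sapiens) for antiproliferative activity, read by sulforhodamine B assay, with a stated time of 72 h (on this read-out lower numbers stand for stronger inhibition and higher numbers for weaker inhibition), compound 1 gives 40000 nM and is the only compound with a true number so far. Compound 2 stands at the limit of > 100000 nM in this assay, at which 1 of the 2 values shown sits, and has no true number. Among the measured compounds shown here, the one measured step, an at least 2.5-fold higher number from compound 1 to compound 2 (0.39 log units; beyond the scatter), replaces the group on the ring amine nitrogen and lies beyond the scatter.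

Compound 3 `Nc1nc(N2CCN(c3ncccn3)CC2)c2ncn([C@@H]3O[C@H](CO)[C@@H](O)[C@H]3O)c2n1` keeps that group of compound 1 and changes another place: amino in place of hydrogen on an aromatic carbon, between two ring nitrogen atoms. For the measured compounds named here, no measured step touches that place, so the step to compound 2 gives only a rough sense of how far one change can move this read-out. From the compounds shown here alone, with compound 1 at 40000 nM as the anchor, no step beyond the scatter is expected in this assay, though either direction stays open and the range is kept wide. For compound 3 the estimated value is 35000 nM, with an expected range from 10000 nM to 100000 nM. That expected value amounts to a 1.1-fold lower number from compound 1 to compound 3 (0.06 log units; within the scatter) in this estimate.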

Compound 3, half-maximal inhibitory concentration: "not active" (no number reported)
For compound 3 the study gives words and no number, so the estimate cannot be set against anything.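

Among these compounds, compound 3 is reported only in words, as "not active", so no step from compound 1 to compound 3 can be read. Still open is how far the amino group moves this read-out, since only compound 1 has a true number and compound 2 stands at a limit, not a number: the limit of > 100000 nM in this assay, at which 1 of the 3 values shown sits.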